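The source may hold more compounds than are shown below. What is called first, only, known or untested is meant among the compounds shown, and "the series" means these compounds.

Measured so far:
compound 1 `O=c1c2c(Nc3ccccc3)nn(-c3ccccc3)c2nc(Nc2ccccc2)n1-c1ccccc1` — 48.1%
compound 2 `NS(=O)(=O)c1ccc(-n2nc(Nc3ccccc3)c3c(=O)n(-c4ccccc4)c(Nc4ccccc4)nc32)cc1` — 60.2%
compound 3 `O=c1c2c(Nc3ccc([N+](=O)[O-])cc3)nn(-c3ccccc3)c2nc(Nc2ccccc2)n1-c1ccccc1` — 29.4%

All three were read in a functional assay on the whole organism (strain Wistar albino) for inhibition, with Rattus norvegicus as the target, read by paw edema, with a stated time of 1 h, at a dose of 25 mg/kg by the oral route; a lower number here means less inhibition, a higher number more inhibition at the dose given (going by the name of the read-out). Compound 1 gives 48.1% in this assay. Compound 2 carries sulfamoyl in place of hydrogen on an aromatic carbon and gives 60.2% in this assay, a change of a number 12.1 percentage points higher from compound 1 to compound 2 (beyond the scatter). Compound 3 carries nitro in place of hydrogen on an aromatic carbon and gives 29.4% in this assay, a change of a number 18.7 percentage points lower from compound 1 to compound 3 (beyond the scatter); it is the lowest of the three numbers, and both of its gaps to the others lie beyond the scatter.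

Compound 4 `NS(=O)(=O)c1ccc(-n2nc(Nc3ccc([N+](=O)[O-])cc3)c3c(=O)n(-c4ccccc4)c(Nc4ccccc4)nc32)cc1` has not yet been measured in this assay. It differs from compound 3 by sulfamoyl in place of hydrogen on an aromatic carbon. This is the same change that turns compound 1 into compound 2, and the place is described in the same words in both cases. The two cores on which the change is made differ by nitro in place of hydrogen on an aromatic carbon. Going by the values given here, only one earlier instance of the change is available, so the expectation rests on a single step, applied to a core that carries the nitro group.

The step from compound 3 to compound 4 is expected to be a number 11.6 percentage points higher from compound 3 to compound 4 (beyond the scatter), of about the size seen as a number 12.1 percentage points higher from compound 1 to compound 2 (beyond the scatter), because compound 2 with this change gave 60.2% in this assay. Compound 4 is therefore expected to give about 41% in this assay, with the estimate ranging from 29% to 53%.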

Compound 4, a percentage reported as inhibition, in the whole organism at one dose (the size of the read-out at that dose, not a potency): 67%
Beside the measured number, compound 4's estimate is 26 percentage points below it, outside the stated range (above it).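

In this assay, sulfamoyl in place of hydrogen gives a number 37.6 percentage points higher from compound 3 to compound 4 (beyond the scatter) on the core carrying the nitro group, so the phenyl to 4-sulfamoylphenyl change keeps its direction on both cores but not its size: the same change on two cores in this assay, a number 12.1 percentage points higher (beyond the scatter) from compound 1 to compound 2 and a number 37.6 percentage points higher (beyond the scatter) from compound 3 to compound 4, 25.5 percentage points apart, beyond the scatter of two such steps

Read from the other side, nitro in place of hydrogen gives a number 6.8 percentage points higher from compound 2 to compound 4 (within the scatter) on the core carrying sulfamoyl, so the drop seen for nitro on the core of compound 1 does not recur once sulfamoyl is present, and the two changes do not simply add in these four compounds: the same change on two cores in this assay, a number 18.7 percentage points lower (beyond the scatter) from compound 1 to compound 3 and a number 6.8 percentage points higher (within the scatter) from compound 2 to compound 4, 25.5 percentage points apart, beyond the scatter of two such steps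

This shows that the size of a step taken on one core is a poor guide to its size on the other in this set, but it rests on two cores and a single dose and time point, and it gives no reason for the dependence and no rule for other cores.

The compounds shown leave open whether this dependence belongs to nitro alone or would also appear with a methoxy group, a chlorine or an amine in its place. They also leave open whether sulfamoyl is specifically required, which a carboxylic acid or a methylsulfonyl group at the same place on the phenyl ring could test.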